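The source may report more compounds than this note shows. Statements on the series, on what has been measured and on what is new or still open speak of the compounds shown alone.

In a functional assay on cells for agonist activity at Free fatty acid receptor 1 (Mus musculus), read by FLIPR and calcium flux, with a stated time of 100 s (on this read-out lower numbers stand for an effect already at smaller amounts and higher numbers for an effect only at larger amounts of compound), the measured compounds are:

compound 1 `O=C(O)C[C@H]1CCCN1c1ccc(OCc2ccc(Cl)cc2Cl)cc1`, whose result is a limit of the assay, > 17000 nM;
compound 2 `Cc1ccccc1Oc1ccc(N2C[C@@H](C(F)(F)F)C[C@H]2CC(=O)O)cc1`, 330 nM;
compound 3 `Cc1ccccc1Oc1ccc(N2CCC[C@H]2CC(=O)O)cc1`, 5600 nM.

Compound 3 holds the highest of the two numbers, and the step of a 17-fold higher number from compound 2 to compound 3 (1.23 log units; beyond the scatter) lies beyond the scatter. Compound 1 stands only as a limit (the limit of > 17000 nM in this assay, at which 1 of the 3 values shown sits), so against compound 3 nothing more can be said than what the two values show.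

Compound 4 `O=C(O)C[C@@H]1CCCN1c1ccc(Oc2ccccc2-c2ccccc2)cc1` differs from compound 3 by phenyl in place of methyl on an aromatic carbon. Going by the values given here, no measured step touches this part of the molecule: the one known step changes a saturated ring carbon, and compound 1 differs from compound 3 in more than one place. The expectation for this assay therefore rests on compound 3 alone, and the step of a 1.9-fold lower number from compound 3 to compound 4 (0.27 log units; within the scatter) is expected to be modest, with the direction uncertain. Compound 4 is estimated at 3000 nM, within the range 600 nM to 15000 nM.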

Compound 4, half-maximal effective concentration: 1300 nM
Estimate against measurement, compound 4: 2.3-fold (0.36 log units) above, within the range that was stated.
By their numbers in this assay, from the lowest: compound 2; then compound 4; then compound 3. At a limit, above all of these: compound 1.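

In this assay, the exchange of methyl for phenyl on an aromatic carbon gives a 4.3-fold lower number from compound 3 to compound 4 (0.63 log units; beyond the scatter). Going by these compounds alone, this is the first sign that this position, ortho to a large group, affects the read-out, as the earlier single change touched only a saturated ring carbon, and it shows that a whole six-membered aromatic ring of carbon only can stand there without the number rising. Nothing measured here explains the shift.

The compounds shown leave open whether methoxy, chlorine or a pyridine ring at this carbon would give a similar number, and whether a phenyl placed elsewhere on the same ring would do the same. They also leave open whether phenyl at this position and trifluoromethyl on the saturated ring would add up within one molecule.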